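Hydroxyphenyl carbamoylamino arm exchanged for chlorophenyl

The source may report more compounds than this note shows. Statements on the series, on what has been measured and on what is new or still open speak of the compounds shown alone.

Going by the values given here, compound 2 `COc1cc(NC(C)CCCNC(=O)NNC(=O)Nc2ccc(O)cc2)c2ncccc2c1` gives 2600 nM in a functional assay on MCF7 cells (Homo sapiens) for inhibition, read by MTT assay, with a stated time of 72 h (on this read-out higher numbers stand for weaker inhibition and lower numbers for stronger inhibition), the highest of the three numbers so far. Compound 1 `COc1cc(NC(C)CCCNC(=O)NNC(=O)Nc2cccc(C(F)(F)F)c2)c2ncccc2c1` gives 190 nM and compound 3 `COc1cc(NC(C)CCCNC(=O)NNC(=O)Nc2ccc(C(F)(F)F)cc2)c2ncccc2c1` gives 100 nM. The step of a 14-fold higher number from compound 1 to compound 2 (1.14 log units; beyond the scatter) and the step of a 26-fold lower number from compound 2 to compound 3 (1.41 log units; beyond the scatter) both set compound 2 apart, whereas a 1.9-fold lower number from compound 1 to compound 3 (0.28 log units; within the scatter) leaves the two trifluoromethyl analogues indistinguishable.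

Compound 4 `COc1cc(NC(C)CCCNC(=O)Nc2cccc(Cl)c2)c2ncccc2c1` differs from compound 2 in one place: 3-chlorophenyl in place of ((4-hydroxyphenyl)carbamoyl)amino on an amide-type nitrogen. The two measured steps that start or end at compound 2 bear on this. Each of them shows that taking the 4-hydroxyphenyl group out of compound 2 in favour of a trifluoromethylphenyl group moves this assay strongly toward lower numbers. In compound 4 the 4-hydroxyphenyl group likewise disappears, and a 3-chlorophenyl group with no hydrogen-bond donors or acceptors enters, so a move in the same direction is expected. Among the compounds with values here, the carbamoylamino part is removed at the same time, and no measured pair covers a shortening of that kind, which widens the range and argues for a smaller step than either measured one. The step of a 7.4-fold lower number from compound 2 to compound 4 (0.87 log units; beyond the scatter) is therefore expected. Compound 4 is estimated at 350 nM, within 80 nM to 1500 nM.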

Compound 4, half-maximal inhibitory concentration: 11000 nM
Estimate against measurement, compound 4: 31-fold (1.50 log units) below; measured number above the stated range.
By their numbers in this assay, from the lowest: compounds 3 and 1 (each within the scatter of the next); then compound 2; then compound 4.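

Working notes: with a 4.2-fold higher number from compound 2 to compound 4 (0.63 log units; beyond the scatter) in this assay, placing 3-chlorophenyl on the amide-type nitrogen in place of ((4-hydroxyphenyl)carbamoyl)amino shifts the read-out toward weaker inhibition. That direction is opposite to a 26-fold lower number from compound 2 to compound 3 (1.41 log units; beyond the scatter), where the carbamoylamino arm stays and only hydroxy gives way to trifluoromethyl, so losing the 4-hydroxyphenyl group does not by itself lower the number at this position, and the gains seen so far belong to changes made with the arm intact. No measurement on hand accounts for the rise, and this single step changes the aromatic group and the length of the arm together, so their shares cannot be separated.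

Going by these compounds alone, still open is how compound 4 would read with only one of those two changes, as with 3-chlorophenyl carried on the full carbamoylamino arm. Also open, on these data alone, is how the intact arm responds when its terminal phenyl ring carries an amine or a carboxylic acid in place of hydroxy or trifluoromethyl, and whether a longer chain on the shared core alters the picture.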